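Thienopyrimidinone series: swapping the bicyclic arm for aminopyridine

A few compounds are considered here, and "the series" means these few. Any claim that something is new, unique, unknown or untested is made for them only; others in the source may bear on it.

Among the measured compounds shown here, compound 2 `O=c1c2cc(-c3ccnc4[nH]ccc34)sc2ncn1Cc1cccc(C(F)(F)F)c1` is the higher of the two numbers so far in an assay on isolated protein for inhibition of Rho-associated protein kinase 1 (Homo sapiens), read by radiometric assay and 33P incorporation, with a stated time of 40 min, in the presence of a further agent that is not named here; on this read-out higher numbers stand for weaker inhibition and lower numbers for stronger inhibition: compound 2 gives 110 nM, whereas compound 1 `O=c1c2cc(-c3ccnc4[nH]ccc34)sc2ncn1Cc1cccc(F)c1` gives 13 nM. For the measured compounds named here, the one measured step, an 8.5-fold higher number from compound 1 to compound 2 (0.93 log units; beyond the scatter), is the trifluoromethyl in place of fluoro on an aromatic carbon and sits at a different place in the molecule from the change considered next.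

Compound 3 `Nc1cc(-c2cc3c(=O)n(Cc4cccc(C(F)(F)F)c4)cnc3s2)ccn1` differs from compound 2 by a group of 7 heavy atoms (5 carbon, 2 nitrogen; one six-membered aromatic ring with 1 hetero atom) in place of a group of 9 heavy atoms (7 carbon, 2 nitrogen; one five-membered aromatic ring with 1 hetero atom, one six-membered aromatic ring with 1 hetero atom), on an aromatic carbon. Going by the values given here, no measured step touches this part of the shared core, so the step from compound 1 to compound 2 gives no guide to its size or direction, and the expectation rests on the change itself: a smaller group of one ring replaces a group of two fused rings, with one donor kept and one more acceptor counted.

For compound 3 in this assay a value of 400 nM is expected, within a range from 60 nM to 3000 nM. That estimate for compound 3 means an expected step of a 3.6-fold higher number from compound 2 to compound 3 (0.56 log units; beyond the scatter), a weaker inhibition, with wide uncertainty.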

Compound 3, half-maximal inhibitory concentration: 490 nM
Compound 3: middle estimate off by 1.2-fold (0.09 log units), on the low side; measured number inside the range.
By their numbers in this assay, from the lowest: compound 1; then compound 2; then compound 3.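

The arm on the aromatic carbon next to the ring sulfur is now shown to respond to change in this assay: 2-aminopyridin-4-yl in place of the two-ring group gives a 4.5-fold higher number from compound 2 to compound 3 (0.65 log units; beyond the scatter). The single ring with its amino group therefore does not hold the level of compound 2, and this position joins the aromatic group bearing fluoro or trifluoromethyl as a second place where a measured change moves the number upward. No data at hand bear on why the number rises at this position.

From the compounds shown here alone, it remains open whether the 2-aminopyridin-4-yl arm loses as much when paired with the fluoro group of compound 1, and so whether the changes at the two places simply add. Going by these compounds, it is also open how much of the step belongs to the amino group rather than to the loss of the second ring, a question that a plain pyridin-4-yl arm, or a methylamino group in place of the amino group, would help to separate.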